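Aryl-nitrogen methoxy pattern in an SJSA-1 inhibition series

This account rests on a few compounds, and the source may have more. Where it says the series, first, only, none or still open, it means among the compounds named here.

Measured so far:
compound 1 `COc1cccc(OC)c1N1C(=O)CSC1c1cccc(C(=O)NCCCCc2ccccc2)c1`: 72%
compound 2 `COc1ccccc1N1C(=O)CSC1C(=O)NCCCCc1ccccc1`: 14%

In a functional assay on SJSA-1 cells (Homo sapiens) for inhibition, read by CCK-8 assay, with a stated time of 72 h, tested at 1 uM (on this read-out lower numbers stand for less inhibition and higher numbers for more inhibition at the one concentration tested (going by the name of the read-out)), compound 1 gives 72%, the higher of the two numbers recorded. Compound 2 gives 14%, lower by a margin beyond the usual scatter. Within the data shown here, compound 2 differs from compound 1 in more than one place, so the measured pair offers no single-point step to lean on.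

Compound 3 `COc1ccc(N2C(=O)CSC2c2cccc(C(=O)NCCCCc3ccccc3)c2)c(OC)c1` is the next entry. It keeps the same atoms as compound 1, joined differently: 2,4-dimethoxyphenyl in place of 2,6-dimethoxyphenyl on an amide-type nitrogen in a ring. Without a measured step of this kind, the expectation for this assay is a modest fall or no change beyond the scatter; a large move in either direction would be a surprise. Compound 3 is estimated at 60%, with a range from 35% to 80%. The estimated step of a number 12 percentage points lower from compound 1 to compound 3 (beyond the scatter) is expected to be small, downward if anything.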

Compound 3, a percentage reported as inhibition, at one concentration (the size of the read-out at that concentration, not a potency): 85%
Compound 3: middle estimate off by 25 percentage points, on the low side; measured number above the stated range.
By their numbers in this assay, from the lowest: compound 2; then compound 1; then compound 3.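

In this assay, 2,4-dimethoxyphenyl in place of 2,6-dimethoxyphenyl on the amide-type nitrogen in a ring gives a number 13 percentage points higher from compound 1 to compound 3 (beyond the scatter) with no change in the atoms present, so the 2,6-dimethoxyphenyl pattern is not required for inhibition at this position. Among these compounds, this is the first single-place step, and it shows that the methoxy arrangement alone can shift the read-out beyond the usual scatter. Nothing available accounts for the gain, and it stands as a plain observation on this one pair.

Open, on these data alone, is whether a plain phenyl, a 3,4-dimethoxyphenyl or a pyridine ring on that nitrogen would keep the level of compound 3. Also open, as far as these compounds go, is whether the step would recur with a carboxylic acid in place of the long amide chain of the shared core.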